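Adding a Methyl to the Difluorocyclohexyl Ring of Compound 3

The source may hold more compounds than are shown below. What is called first, only, known or untested is meant among the compounds shown, and "the series" means these compounds.

Compound 1, `C(=C/C1CCCCC1)\c1nc2cc(-c3ccccc3)ccc2[nH]1`, gives 110 nM in a functional assay on HEK293 cells for antagonist activity at transient receptor potential M8 protein (Canis lupus familiaris), read by FLIPR and calcium flux; on this read-out higher numbers stand for weaker inhibition and lower numbers for stronger inhibition.
Compound 2, `FC(F)(F)Oc1ccccc1-c1ccc2[nH]c(/C=C/C3CCCCC3)nc2c1`, gives 14 nM in this assay.
Compound 3, `FC1(F)CCC(/C=C/c2nc3cc(-c4ccccc4C(F)(F)F)ccc3[nH]2)CC1`, gives 21 nM in this assay.

Among these three numbers, compound 3 stands second highest. Its value lies within the scatter of the value of compound 2, so the two cannot be told apart on this read-out, while compound 1 gives a higher number that lies beyond the scatter of compound 3.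

Compound 4, `CC1(/C=C/c2nc3cc(-c4ccccc4C(F)(F)F)ccc3[nH]2)CCC(F)(F)CC1`, arises from compound 3 by a single change: methyl in place of hydrogen on a saturated ring carbon. Among the compounds with values here, only one measured step is available, a 7.9-fold lower number from compound 1 to compound 2 (0.90 log units; beyond the scatter), and it concerns a trifluoromethoxy group on an aromatic carbon of the shared core, not a methyl on the saturated ring. Within the data shown here, no measured step touches the six-membered non-aromatic ring that bears the two fluoro groups, so nothing here shows whether a methyl on that ring moves the number either way. The expectation for compound 4 in this assay is therefore a step that stays within the scatter, a 1.0-fold higher number from compound 3 to compound 4 (0.02 log units; within the scatter). Compound 4 is estimated at 22 nM, with a range from 8 nM to 60 nM.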

Compound 4, half-maximal inhibitory concentration: 8.9 nM
Compound 4: the middle estimate sits 2.5-fold (0.39 log units) above what was measured; measured number inside the range.
By their numbers in this assay, from the lowest: compounds 4, 2 and 3 (each within the scatter of the next, the first and the last beyond it); then compound 1.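

In this assay, within the data shown here, the change recorded as a 2.4-fold lower number from compound 3 to compound 4 (0.37 log units; beyond the scatter) is the first measured step on the saturated ring, and it lies beyond the scatter, so the read-out does respond to what sits on this ring carbon. At this carbon, three ring bonds from the ring atom that bears the two fluoro groups, a single added methyl goes with a lower number and so with stronger inhibition, though the step is modest in size. Nothing measured here gives a reason for this step, which therefore stands as an observation without a cause.

From the compounds shown here alone, whether a longer chain such as ethyl, or a hydroxyl or an amine, on this same carbon would lower the number further or reverse the step remains open. Among these compounds, also open is whether methyl would give a step of similar size on a ring without the two fluoro groups, since the only pair that reads this change carries both of them and shares one group on its outer aromatic ring.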